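Piperazine-linked benzothiazole amides: pyridyl for aminoalkyl

A few compounds are considered here, and "the series" means these few. Any claim that something is new, unique, unknown or untested is made for them only; others in the source may bear on it.

Measured compounds:
compound 1 `Cc1cccc2sc(NC(=O)CCN3CCN(CCCN(C)C)CC3)nc12` — 18100 nM
compound 2 `CCCCCCN1CCN(CCC(=O)Nc2nc3c(C)cccc3s2)CC1` — no result reported
compound 3 `Cc1cccc2sc(NC(=O)CCN3CCN(CCN(C(C)C)C(C)C)CC3)nc12` — no result reported

The one figure in an assay on HEK293 cells for antagonist activity at P2X purinoceptor 7 (Homo sapiens), read by fluorescence, with stated times of 30 min and 120 min (a lower number here means a stronger inhibitor, a higher number a weaker inhibitor), comes from compound 1, which gives 18100 nM. Compound 2 returned no result reported. Compound 3 likewise returned no result reported, so compound 3 stands without a value and without a step to any measured neighbour; compound 1 alone shows that the series sits in a weak region.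

Compound 4 `Cc1cccc2sc(NC(=O)CCN3CCN(c4ccncc4)CC3)nc12` differs from compound 3 by pyridin-4-yl in place of 2-(diisopropylamino)ethyl on an amine nitrogen in a ring. Going by the values given here, no step between measured compounds exists in this set, so the size of this change cannot be read from the series, and no direction beyond the scatter is assumed. Compound 4 is expected in this assay to remain in the weak region of compound 1, estimated at 15000 nM within 3000 nM to 60000 nM.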

Compound 4, half-maximal inhibitory concentration: 1130 nM
The estimate for compound 4 lay 13-fold (1.12 log units) above the measured number, outside the stated range (below it).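

In this assay, going by these compounds alone, pyridin-4-yl in place of 3-(dimethylamino)propyl on an amine nitrogen in a ring gives a 16-fold lower number from compound 1 to compound 4 (1.20 log units; beyond the scatter), the first evidence that this position can move the number beyond the scatter and that the series is not confined to its weak region. Compound 3 has no number, so its step to compound 4 cannot be read. Nothing measured here accounts for the change.

Open, going by these compounds, is whether phenyl or pyridin-3-yl on the same nitrogen would keep the lower number. A longer chain ending in pyridin-4-yl also remains to be placed.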